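The source may report more compounds than this note shows. Statements on the series, on what has been measured and on what is new or still open speak of the compounds shown alone.

Going by the values given here, in an ADME assay on HEK293 cells (Homo sapiens) for cytotoxicity, read by MTT assay, with a stated time of 48 h (on this read-out higher numbers stand for weaker inhibition and lower numbers for stronger inhibition), compound 1 `CN(C)CCn1c(N)c(-c2nc3ccccc3[nH]2)c2nc(C#N)c(C#N)nc21` gives 9730 nM, the only number among the two values shown. Compound 2 `CCCCn1c(N)c(-c2nc3ccccc3[nH]2)c2nc(C#N)c(C#N)nc21` reaches only the limit of > 50000 nM in this assay. Among the compounds with values here, the one measured step, an at least 5.1-fold higher number from compound 1 to compound 2 (0.71 log units; beyond the scatter), ends at the limit of > 50000 nM in this assay, at which 1 of the 2 values shown sits. Compound 3 `N#Cc1nc2c(-c3nc4ccccc4[nH]3)c(N)n(CCCN3CCCCC3)c2nc1C#N` differs from compound 1 by (piperidin-1-yl)methyl in place of dimethylamino on a saturated chain carbon, two bonds along the chain from an aromatic nitrogen. Unlike the step to compound 2, this change keeps a chain nitrogen, so no step beyond the scatter is expected in this assay. Compound 3 is therefore estimated at 7000 nM, between 2500 nM and 20000 nM. The expected step is a 1.4-fold lower number from compound 1 to compound 3 (0.14 log units; within the scatter).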

Compound 3, half-maximal inhibitory concentration: 6720 nM
Estimate against measurement, compound 3: 1.0-fold (0.02 log units) above; the range from low to high includes it.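

In this assay, replacing 2-(dimethylamino)ethyl with 3-(piperidin-1-yl)propyl leaves the read-out within the scatter, at a 1.4-fold lower number from compound 1 to compound 3 (0.16 log units; within the scatter), so this position tolerates the longer chain with its ring amine. Piperidin-1-yl in place of the terminal methyl gives an at least 7.4-fold lower number from compound 2 to compound 3 (0.87 log units; beyond the scatter), a second pair in which the compound with a chain nitrogen carries the lower number. The value of compound 2 is a limit, so the full size of that step stays unknown: the limit of > 50000 nM in this assay, at which 1 of the 3 values shown sits.

On these data alone, it remains open how a 3-(dimethylamino)propyl chain would read, which would separate chain length from the ring. A morpholine or a carboxylic acid at the chain end also remains untested among the compounds shown.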